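Extending an Amide Side Chain from Propyl to Hexyl

The source may report more compounds than this note shows. Statements on the series, on what has been measured and on what is new or still open speak of the compounds shown alone.

Three amides sharing one core have been tested in a functional assay on the whole organism (strain Wistar) for inhibition, with Rattus norvegicus as the target, read by paw edema, with stated times of 60 min and 2 h, at a dose of 100 mg/kg by the oral route; on this read-out lower numbers stand for less inhibition and higher numbers for more inhibition at the one dose given (going by the name of the read-out). Compound 1 `CCN(CC)C(=O)CC1CCc2cc(OC)c(OC)cc21` gives 40%, compound 2 `CCCNC(=O)CC1CCc2cc(OC)c(OC)cc21` gives 28%, and compound 3 `CCCCCNC(=O)CC1CCc2cc(OC)c(OC)cc21` gives 34%. Compound 2 thus holds the lowest of the three numbers, with compound 3 nearest, within the scatter, and compound 1 further off, as the step of a number 12 percentage points lower from compound 1 to compound 2 (beyond the scatter) shows. Compound 4 `CCCCCCNC(=O)CC1CCc2cc(OC)c(OC)cc21` differs from compound 2 by propyl in place of hydrogen on a saturated chain carbon, three bonds along the chain from an amide-type nitrogen. The closest measured guide is the step of a number 6 percentage points higher from compound 2 to compound 3 (within the scatter), which also lengthens this chain and stays within the scatter; a number 6 percentage points lower from compound 1 to compound 3 (within the scatter) likewise stays within the scatter. A further lengthening is therefore expected to move the number only slightly, by about a number 6 percentage points higher from compound 2 to compound 4 (within the scatter). Compound 4 is estimated at 34%, between 22% and 46%.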

Compound 4, a percentage reported as inhibition, in the whole organism at one dose (the size of the read-out at that dose, not a potency): 41.5%
Compound 4: middle estimate off by 7.5 percentage points, on the low side, within the range that was stated.
By their numbers in this assay, from the lowest: compounds 2, 3, 1 and 4 (each within the scatter of the next, the first and the last beyond it).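

In this assay, lengthening the chain on the amide nitrogen now gives a step beyond the scatter (a number 13.5 percentage points higher from compound 2 to compound 4 (beyond the scatter)), which the pentyl chain alone did not give, although the last addition of one methyl stays within it (a number 7.5 percentage points higher from compound 3 to compound 4 (within the scatter)). The hexylamino amide also stands level with the diethylamino amide (a number 1.5 percentage points higher from compound 1 to compound 4 (within the scatter)), so the gap seen with propylamino does not persist at this chain length. Nothing measured here explains the change. On these data alone, whether a longer chain, such as octyl, carries the trend further remains open, as does the effect of an amine or a carboxylic acid at the chain end.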